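The source may hold more compounds than are shown below. What is called first, only, known or untested is meant among the compounds shown, and "the series" means these compounds.

Compound 1, `CCCCCCCCCCC[C@@H](C[C@@H]1OC(=O)[C@H]1CCCCCC)OC(=O)[C@H](CC(C)C)NC(=O)OC(C)(C)C`: in an assay on membranes from brain for inhibition of Fatty-acid amide hydrolase 1 (Rattus norvegicus) (a higher number here means a weaker inhibitor, a lower number a stronger inhibitor), compound 1 gives > 50000 nM, which is a limit of the assay rather than a number.
Compound 2, `CCCCCCCCCCC[C@@H](C[C@@H]1OC(=O)[C@H]1CCCCCC)OC(=O)CNC(=O)OCc1ccccc1`: compound 2 gives > 50000 nM, also a limit.
Compound 3, `CCCCCCCCCCC[C@@H](C[C@@H]1OC(=O)[C@H]1CCCCCC)OC(=O)[C@H](C)NC=O`: compound 3 gives > 50000 nM, again a limit.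

Compound 3 therefore stands at the limit of this assay, the point at which every value shown sits (the limit of > 50000 nM in this assay, at which 3 of the 3 values shown sit). Compound 4, `CCCCCCCCCCC[C@@H](C[C@@H]1OC(=O)[C@H]1CCCCCC)OC(=O)[C@@H]1CCCN1C=O`, differs from it by a group of 7 heavy atoms (5 carbon, 1 nitrogen, 1 oxygen; one five-membered non-aromatic ring with 1 hetero atom) in place of a group of 5 heavy atoms (3 carbon, 1 nitrogen, 1 oxygen; no ring), on a carbonyl carbon. Among the measured compounds shown here, the only measured step, a step that the two limits leave unreadable from compound 2 to compound 3, cannot be read: both of its ends are limits. No step beyond the scatter can thus be foreseen, and compound 4 is expected to stay at the limit, giving an estimated step that the limit leaves unreadable from compound 3 to compound 4. Compound 4 is estimated at 60000 nM, within a range from 20000 nM to 200000 nM.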

Compound 4, half-maximal inhibitory concentration: 3400 nM
Beside the measured number, compound 4's estimate is 18-fold (1.25 log units) above it; measured number below the stated range.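

On this carbonyl carbon, 1-formylpyrrolidin-2-yl gives an at least 14-fold lower number from compound 3 to compound 4 (1.16 log units; beyond the scatter) in this assay, and in place of ((benzyloxycarbonyl)amino)methyl it gives an at least 14-fold lower number from compound 2 to compound 4 (1.16 log units; beyond the scatter). Among the compounds shown here, the step from compound 2 to compound 3 cannot be read, so this is the first sign that the group at this place can change the result. Compound 4 alone leaves the limit: the limit of > 50000 nM in this assay, at which 3 of the 4 values shown sit.

The change adds a ring and removes the hydrogen-bond donor at once, and the compounds shown do not separate the two. Also open, as far as these compounds go, is how a six-membered piperidine ring, or an acetyl group in place of the formyl group, would fare.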